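The source may hold more compounds than are shown below. What is called first, only, known or untested is meant among the compounds shown, and "the series" means these compounds.

Of the compounds shown here, three that share one core have so far been tested in a functional assay on NB-4 cells (Homo sapiens) for cytotoxicity, read by CCK-8 assay, with a stated time of 24 h; a higher number here means a weaker inhibitor, a lower number a stronger inhibitor. Compound 1 `C=CC(=O)N1C(=O)CC(c2ccc(C(F)(F)F)cc2)Sc2ccccc21` gives 38600 nM. Compound 3 `C=CC(=O)N1C(=O)CC(c2ccccc2C(F)(F)F)Sc2ccccc21` differs from it only in where the trifluoromethyl sits on the aromatic ring and gives 35200 nM, so these two numbers lie within the scatter of each other. Compound 2 `C=CC(=O)N1C(=O)CC(C)Sc2ccccc21` has a methyl group where the other two carry that aromatic ring and gives 227000 nM, a clearly higher number than either. Compound 1 therefore stands level with compound 3 and well clear of compound 2.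

Compound 4 `C=CC(=O)N1C(=O)CC(c2ccc(-c3ccccc3)cc2)Sc2ccccc21` has not yet been measured. It keeps the whole of compound 1 except for one change: phenyl in place of trifluoromethyl on an aromatic carbon, para to a large group (phenyl in place of trifluoromethyl on an aromatic carbon). Among the compounds with values here, no measured pair shows this swap directly, so any expectation is loose. The one large gap so far appears with compound 2 at 227000 nM, which lacks the aromatic ring that compound 4 keeps. In this assay the expected change a 1.3-fold lower number from compound 1 to compound 4 (0.11 log units; within the scatter) stays within the scatter, with no firm direction. Compound 4 is estimated at 30000 nM, with an expected range from 12000 nM to 80000 nM.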

Compound 4, half-maximal inhibitory concentration: 57700 nM
Compound 4: middle estimate off by 1.9-fold (0.28 log units), on the low side; low and high end bracket the measured number.
By their numbers in this assay, from the lowest: compounds 3, 1 and 4 (each within the scatter of the next); then compound 2.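

In this assay the swap of trifluoromethyl for phenyl on an aromatic carbon, para to a large group, gives a 1.5-fold higher number from compound 1 to compound 4 (0.17 log units; within the scatter) and so does not separate the two compounds. This position therefore accepts a group with more heavy atoms, including a whole extra aromatic ring of carbon, without a clear shift in the number. The earlier compounds shown here could not show this, as they differ only in where the trifluoromethyl sits or in a methyl group replacing the aromatic ring. No measurement here bears on why trifluoromethyl and phenyl read alike at this place.

From the compounds shown here alone, it remains open whether a group of a different kind at this same place, such as an amine or a carboxylic acid, would keep the number close to that of compound 1 or shift it clearly beyond the scatter. Going by these compounds, it is also open whether a longer chain where compound 2 carries its methyl group would read closer to compound 2 or to the compounds that keep the aromatic ring.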